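A few compounds are considered here, and "the series" means these few. Any claim that something is new, unique, unknown or untested is made for them only; others in the source may bear on it.

Compound 1 `CCCCCOC(=O)N1CCN(C(=O)c2nc(Nc3cc(C4CC4)[nH]n3)c3cc(Cl)ccc3n2)C[C@H]1C`: in an assay for inhibition of serine/threonine-protein kinase PAK 4 (Homo sapiens), read by FRET and Z'-LYTE, with a stated time of 60 min, tested at 0.5 uM, in the presence of a further agent that is not named here (a higher number here means a stronger effect of the compound at the concentration tested, a lower number a weaker effect), compound 1 gives -3.8%.
Compound 2 `C[C@@H]1CN(C(=O)c2nc(Nc3cc(C4CC4)[nH]n3)c3cc(Cl)ccc3n2)CCN1C(=O)OCc1ccccc1`: compound 2 gives 4.4%.
Compound 3 `CC(C)OC(=O)N1CCN(C(=O)c2nc(Nc3cc(C4CC4)[nH]n3)c3cc(Cl)ccc3n2)C[C@H]1C`: compound 3 gives 26.9%.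

The three compounds share one core and differ only in the group carried on the oxygen next to a carbonyl group. Compound 1 has the lowest of the three numbers. Its nearest neighbour is compound 2, a number 8.2 percentage points higher from compound 1 to compound 2 (within the scatter), a gap that lies within the scatter. Its furthest is compound 3, a number 30.7 percentage points higher from compound 1 to compound 3 (beyond the scatter). Between the other two, a number 22.5 percentage points higher from compound 2 to compound 3 (beyond the scatter).

Compound 4 `CC(C)C(=O)OCOC(=O)N1CCN(C(=O)c2nc(Nc3cc(C4CC4)[nH]n3)c3cc(Cl)ccc3n2)C[C@H]1C` has not been measured in this assay. Compared with compound 1 the change is (isopropylcarbonyl)oxy in place of butyl on a saturated chain carbon bound to an oxygen next to a carbonyl group. Within the data shown here, no measured step contains this entering group, so the two changes made at the same place must serve as guides. Swapping butyl for phenyl there, a number 8.2 percentage points higher from compound 1 to compound 2 (within the scatter), stayed within the scatter, and the only step beyond the scatter, a number 30.7 percentage points higher from compound 1 to compound 3 (beyond the scatter), came from cutting the chain down to isopropyl rather than from exchanging one chain end for another. As compound 4 again carries a group of comparable size at that position, the expected step is a number 7.8 percentage points higher from compound 1 to compound 4 (within the scatter), not beyond the scatter. Compound 4 is therefore estimated at 4%, within a range from -14% to 24%.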

Compound 4, a percentage reported as inhibition, at one concentration (the size of the read-out at that concentration, not a potency): 16.4%
Beside the measured number, compound 4's estimate is 12.4 percentage points below it; the measured number falls inside the stated range.
By their numbers in this assay, from the lowest: compounds 1 and 2 (each within the scatter of the next); then compound 4; then compound 3.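

Among these compounds, the earlier compounds left cutting the chain down to isopropyl as the only change that moved the number beyond the scatter, but compound 4 shows a second route: in this assay, a larger group, (isopropylcarbonyl)oxy, replacing butyl gives a number 20.2 percentage points higher from compound 1 to compound 4 (beyond the scatter), and replacing phenyl gives a number 12 percentage points higher from compound 2 to compound 4 (beyond the scatter). So among these four compounds, the size of the group at this place does not alone set the number, although isopropyl keeps the top place, with ((isopropylcarbonyl)oxy)methyl giving a number 10.5 percentage points lower from compound 3 to compound 4 (beyond the scatter). Nothing available here explains why this group behaves differently from butyl and phenyl at this place.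

The compounds shown leave open whether the number depends on the ester carbonyl inside the new group, a question that a plain methoxymethyl group on the oxygen next to a carbonyl group could help to settle. They also leave open whether another small branched or short group there, such as tert-butyl or ethyl, would match or pass isopropyl in compound 3.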